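A chlorobenzyl sulfide moved one carbon around

The source may hold more compounds than are shown below. What is called first, only, known or untested is meant among the compounds shown, and "the series" means these compounds.

Measured so far:
compound 1 `CC1=C(C(=O)Nc2ccc(F)cc2)C(c2ccc([N+](=O)[O-])cc2)N=C(SCc2ccc(F)cc2)N1` with 17%
compound 2 `CC1=C(C(=O)Nc2ccc(Br)cc2)C(c2ccc(Cl)cc2Cl)N=C(SCc2ccccc2)N1` with 10.3%
compound 3 `CC1=C(C(=O)Nc2ccc(Br)cc2)C(c2ccc(Cl)cc2Cl)N=C(SCc2ccccc2Cl)N1` with 16%

In a functional assay on the whole organism (artery, strain albino) with Rattus norvegicus as the target, with a stated time of 120 min, at a dose of 10 mg/kg by the oral route (a higher number here means more inhibition at the dose given (going by the name of the read-out), a lower number less inhibition), compound 3 stands second highest of the three numbers. Its nearest neighbour is compound 1, whose number lies within the scatter of that of compound 3; the furthest is compound 2, whose number is lower by the step of a number 5.7 percentage points higher from compound 2 to compound 3 (within the scatter), also within the scatter. For the measured compounds named here, that step, chloro in place of hydrogen on an aromatic carbon, is the only measured change on the same benzyl ring that compound 4 `CC1=C(C(=O)Nc2ccc(Br)cc2)C(c2ccc(Cl)cc2Cl)N=C(SCc2cccc(Cl)c2)N1` now alters: 3-chlorophenyl in place of 2-chlorophenyl on a saturated chain carbon bound to a sulfur. Going by the values given here, no measured pair compares two positions of the chlorine on that ring, so the only guide is that adding the chlorine at all moved the number by less than the scatter. The expectation for this assay is therefore a step of about a number 1 percentage points lower from compound 3 to compound 4 (within the scatter), nothing beyond the scatter. Compound 4 is estimated at 15%, with a range from 5% to 27%.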

Compound 4, a percentage reported as inhibition, in the whole organism at one dose (the size of the read-out at that dose, not a potency): 8.8%
Estimate against measurement, compound 4: 6.2 percentage points above, and the stated range covers the measured number.
By their numbers in this assay, from the lowest: compounds 4, 2, 3 and 1 (each within the scatter of the next).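

In this assay two positions of the chlorine on the benzyl ring can now be compared directly: 3-chlorophenyl in place of 2-chlorophenyl gives a small step (a number 7.2 percentage points lower from compound 3 to compound 4 (within the scatter)). Set against the plain benzyl group, the 3-chlorobenzyl group also gives a small step (a number 1.5 percentage points lower from compound 2 to compound 4 (within the scatter)), so neither chlorine position stands apart from hydrogen beyond the scatter, and these three benzyl groups cannot be told apart here. No measurement at hand offers an explanation for these small differences. Still open, on these data alone, is whether a different group on this ring, such as an amine or a carboxylic acid, would move the number beyond the scatter. Equally open, as far as these compounds go, is what a longer chain in place of the benzyl group would do.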